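Methyl for Methoxy on Compound 2: Expecting Another Limit

The compounds below may be only part of what the source reports. "The series", "measured", "known", "first", "only" and "open" are said of these compounds alone.

Three amides have been measured in a functional assay on SK-HEP1 cells (Homo sapiens) for antiproliferative activity, read by sulforhodamine B assay; a higher number here means a weaker inhibitor of growth, a lower number a stronger inhibitor of growth. Compound 1 `O=C(Nc1nc2ccc([N+](=O)[O-])cc2s1)c1ccc(C(F)(F)F)cc1` gives 2.1 ug/mL. Compound 2 `COc1ccc(C(=O)Nc2nc3cc(C)cc(C)c3s2)cc1` reaches only a limit of the assay, reported as > 10 ug/mL. Compound 3 `COc1cccc2sc(NC(=O)c3ccc([N+](=O)[O-])cc3)nc12` likewise stops at a limit, reported as > 10 ug/mL. Compound 2 thus stands at the limit of > 10 ug/mL in this assay, at which 2 of the 3 values shown sit, with no number of its own. Compound 4 `Cc1ccc(C(=O)Nc2nc3cc(C)cc(C)c3s2)cc1` keeps the core of compound 2 and alters one group: methyl in place of methoxy on an aromatic carbon, a methyl in place of methoxy on an aromatic carbon. Among the compounds with values here, no step between measured compounds is available, and a change of this size is expected to shift the read-out in this assay by nothing beyond the usual scatter, in no clear direction. Compound 4 is therefore estimated at 12 ug/mL, within 5 ug/mL to 30 ug/mL. The expected step that the limit leaves unreadable from compound 2 to compound 4 is essentially none.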

Compound 4, concentration for 50% growth inhibition: 2.17 ug/mL
Estimate against measurement, compound 4: 5.5-fold (0.74 log units) above; measured number outside the range, below it.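

Within the data shown here, on the shared core, this single change at the aromatic carbon para to a large group is the first to give a readable difference: methyl in place of methoxy brings an at least 4.6-fold lower number from compound 2 to compound 4 (0.66 log units; beyond the scatter) in this assay, so this position is not silent to substitution. Compound 2 has no number of its own, so the true size of the step stays hidden and only its lower bound is known: the limit of > 10 ug/mL in this assay, at which 2 of the 4 values shown sit.

From the compounds shown here alone, whether an ethyl chain, a hydroxyl or an amine at this carbon would hold the growth inhibition remains open. The compounds shown also cannot separate the loss of the oxygen from any other part of the change.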